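This account rests on a few compounds, and the source may have more. Where it says the series, first, only, none or still open, it means among the compounds named here.

Among the measured compounds shown here, three amides on the shared core carry numbers so far. Compound 1 `CCCC(=O)N1CCC(NS(=O)(=O)c2ccc(NC(=O)CC3CCCC3)c3ccccc23)CC1` gives 145 nM in an in vitro functional assay on CHO/Galpha16 cells for antagonist activity at C-C chemokine receptor type 8 (Homo sapiens), read by FLIPR; a lower number here means a stronger inhibitor, a higher number a weaker inhibitor. Compound 2 `CCCC(=O)N1CCC(NS(=O)(=O)c2ccc(NC(=O)c3cccc(C)c3)c3ccccc23)CC1` gives 5.1 nM, and compound 3 `CCCCc1ccc(C(=O)Nc2ccc(S(=O)(=O)NC3CCN(C(=O)CCC)CC3)c3ccccc23)cc1` gives 15.3 nM. Compound 3 thus holds the second highest of the three numbers: the nearer neighbour is compound 2, with a 3.0-fold higher number from compound 2 to compound 3 (0.48 log units; beyond the scatter), the further one compound 1, with a 9.5-fold lower number from compound 1 to compound 3 (0.98 log units; beyond the scatter).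

The next compound, compound 4 `CCCC(=O)N1CCC(NS(=O)(=O)c2ccc(NC(=O)c3cccnc3)c3ccccc23)CC1`, differs from compound 3 in one place: pyridin-3-yl in place of 4-butylphenyl on a carbonyl carbon. For the measured compounds named here, two measured steps bear on the amide substituent. Both aryl replacements of cyclopentylmethyl lowered the number strongly, a 28-fold lower number from compound 1 to compound 2 (1.45 log units; beyond the scatter) and a 9.5-fold lower number from compound 1 to compound 3 (0.98 log units; beyond the scatter), so an aromatic group on this carbonyl carbon sits well within the stronger range. The exchange of one aryl for another was modest, a 3.0-fold higher number from compound 2 to compound 3 (0.48 log units; beyond the scatter). Going by the values given here, no step here covers a six-membered aromatic ring with a hetero atom, so the size of the move from 4-butylphenyl to pyridin-3-yl is open; a change within the scatter or a modest shift in either direction is expected. For compound 4 the estimate in this assay is 20 nM, with a range of 5 nM to 80 nM, which is expected to mean a 1.3-fold higher number from compound 3 to compound 4 (0.12 log units; within the scatter).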

Compound 4, half-maximal inhibitory concentration: 885 nM
Compound 4: the middle estimate sits 44-fold (1.65 log units) below what was measured; the measured number lies above the stated range.
By their numbers in this assay, from the lowest: compound 2; then compound 3; then compound 1; then compound 4.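

On this carbonyl carbon, a six-membered aromatic ring does not by itself keep the number low in this assay: pyridin-3-yl is far weaker than either carbon-only aryl group (a 58-fold higher number from compound 3 to compound 4 (1.76 log units; beyond the scatter); a 170-fold higher number from compound 2 to compound 4 (2.24 log units; beyond the scatter)). Compound 4 also lies on the weaker side of the cyclopentylmethyl amide (a 6.1-fold higher number from compound 1 to compound 4 (0.79 log units; beyond the scatter)), so the gain from an aryl group holds for compound 2 and compound 3, while compound 4 goes against it. No measurement shown accounts for the drop.

Pyridin-3-yl differs from both aryl groups in its ring nitrogen and in lacking a carbon substituent, and the compounds shown do not separate these two differences. Unsubstituted phenyl, or pyridin-3-yl carrying a methyl or butyl group, would address that question.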